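The compounds below may be only part of what the source reports. "The series", "measured", "known", "first", "only" and "open" are said of these compounds alone.

Measured so far:
compound 1 `O=C(Nc1ccc(Oc2ccnc3[nH]ccc23)c(F)c1)c1nn(-c2ccc(Cl)c(C(F)(F)F)c2)ccc1=O` — 5500 nM
compound 2 `Cc1cc(=O)n(-c2ccc(F)cc2)nc1C(=O)Nc1ccc(Oc2ncnc3[nH]ccc23)cc1` — > 60000 nM
compound 3 `Cc1cc(=O)n(-c2cccc(F)c2)nc1C(=O)Nc1ccc(Oc2ncnc3[nH]ccc23)cc1` — 14600 nM

In a functional assay on PC-3 cells (Homo sapiens) for cytotoxicity, read by MTT assay, with a stated time of 72 h (a higher number here means a weaker inhibitor, a lower number a stronger inhibitor), compound 3 gives 14600 nM, the highest of the two numbers shown; the nearest is compound 1 at 5500 nM, which is an at least 4.1-fold lower number from compound 2 to compound 3 (0.61 log units; beyond the scatter) lower in kind only, since that step concerns a different pair. For compound 2 the assay reports only a limit, > 60000 nM, and not a number. For the measured compounds named here, the one measured step that touches the ring on the aromatic nitrogen runs an at least 4.1-fold lower number from compound 2 to compound 3 (0.61 log units; beyond the scatter), so moving the fluorine from the 4- to the 3-position made a stronger inhibitor. Compound 4 `Cc1ccc(-n2nc(C(=O)Nc3ccc(Oc4ncnc5[nH]ccc45)cc3)c(C)cc2=O)cc1` is not yet measured; it differs from compound 3 as follows: 4-methylphenyl in place of 3-fluorophenyl on an aromatic nitrogen. The substituent therefore returns to the 4-position, the arrangement that in compound 2 reached only a limit, though with methyl rather than fluorine. Compound 4 is accordingly expected to be a weaker inhibitor than compound 3, with a step of about a 2.4-fold higher number from compound 3 to compound 4 (0.38 log units; beyond the scatter) in this assay. The estimate for compound 4 is 35000 nM, within a range from 10000 nM to 90000 nM.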

Compound 4, half-maximal inhibitory concentration: 9610 nM
The estimate for compound 4 lay 3.6-fold (0.56 log units) above the measured number, and the stated range ends above it.
By their numbers in this assay, from the lowest: compounds 1, 4 and 3 (each within the scatter of the next, the first and the last beyond it). At a limit, above all of these: compound 2.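

In this assay the change to 4-methylphenyl gives a 1.5-fold lower number from compound 3 to compound 4 (0.18 log units; within the scatter), so on this aromatic nitrogen that group and 3-fluorophenyl cannot be told apart. The earlier step had tied the better result to 3-fluorophenyl over 4-fluorophenyl, but methyl in place of fluoro gives an at least 6.2-fold lower number from compound 2 to compound 4 (0.79 log units; beyond the scatter), so a group on the 4-position of this phenyl ring does not in itself go with the weak result of compound 2. Compound 2 gives only a limit of the assay, not a number: the limit of > 60000 nM in this assay, at which 1 of the 4 values shown sits.

The compounds shown leave open how far the true value of compound 2 lies from that limit, and so the full size of this step. They also leave open whether an amine or a methoxy group on this phenyl ring would give a number like that of compound 4.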